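Removing One Chloro Group: From Compound 2 to Compound 3

The source may report more compounds than this note shows. Statements on the series, on what has been measured and on what is new or still open speak of the compounds shown alone.

Compound 1 `ClCc1ccccc1Cn1cnc2c(Cl)ncnc21` gives 32400 nM in a functional assay on A498 cells (Homo sapiens) for cytotoxicity, read by sulforhodamine B assay, with a stated time of 48 h; a higher number here means a weaker inhibitor of growth, a lower number a stronger inhibitor of growth.
Compound 2 `ClCc1ccc(Cn2cnc3nc(Cl)nc(Cl)c32)cc1` gives 23400 nM in this assay.

Of these two numbers, compound 2 has the lower one, but its gap to compound 1 lies within the scatter of the measurement, so the two compounds cannot be told apart on growth inhibition. Compound 3 `ClCc1ccc(Cn2cnc3ncnc(Cl)c32)cc1` has not yet been measured. It differs from compound 2 in one place: hydrogen in place of chloro on an aromatic carbon, in words hydrogen in place of chloro on an aromatic carbon. Within the data shown here, no pair of measured compounds shows what such a change does, so the data themselves give no direction. The expectation is a small step in this assay, if anything toward a higher number, and not clearly beyond the scatter; the step is estimated as a 1.3-fold higher number from compound 2 to compound 3 (0.11 log units; within the scatter). Compound 3 is expected to give 30000 nM, within a range from 10000 nM to 90000 nM.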

Compound 3, concentration for total growth inhibition: 3380 nM
For compound 3 the middle estimate is 8.9-fold (0.95 log units) above the measured one; the measured number lies below the stated range.
By their numbers in this assay, from the lowest: compound 3; then compounds 2 and 1 (each within the scatter of the next).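

In this assay, placing hydrogen instead of chloro on the aromatic carbon between two ring nitrogen atoms gives a 6.9-fold lower number from compound 2 to compound 3 (0.84 log units; beyond the scatter) and so marks a stronger inhibitor of growth. Among these compounds, this is the first step that rises beyond the scatter, and it shows that this position can affect growth inhibition and that the chloro group there is not needed for it. Nothing available explains why the change has this effect.

At this position the compounds shown compare only chloro and hydrogen, so what an amine, a methoxy group or a longer chain would do there remains open. A single pair also leaves open whether the same change would give a similar step in compounds with other groups elsewhere on the molecule.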